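Para-methoxy on the benzoyl group: a small change

The compounds below may be only part of what the source reports. "The series", "measured", "known", "first", "only" and "open" are said of these compounds alone.

Measured so far:
compound 1, `O=C(O)COc1cccc(CCCn2cc(C(c3ccc(Cl)cc3)c3ccc(Cl)cc3)ccc2=O)c1`, > 1000 nM in an assay on HEK293 cells for displacement of a labelled ligand from chemoattractant receptor-homologous molecule expressed on Th2 cells (Cavia porcellus), read by scintillation counting, with a stated time of 2 h; a higher number here means a weaker inhibitor, a lower number a stronger inhibitor
compound 2, `O=C(O)COc1cccc(CCCN(CCC(c2ccccc2)c2ccccc2)C(=O)c2ccccc2)c1`, 18 nM in this assay

The value for compound 1 is a limit of this assay, not a number (the limit of > 1000 nM in this assay, at which 1 of the 2 values shown sits). Compound 2 therefore stands alone as the only real number shown; the other value is a limit.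

Compound 3, `COc1ccc(C(=O)N(CCCc2cccc(OCC(=O)O)c2)CCC(c2ccccc2)c2ccccc2)cc1`, differs from compound 2 in one place: methoxy in place of hydrogen on an aromatic carbon. In words, methoxy in place of hydrogen on an aromatic carbon, which turns the benzoyl into a (4-methoxyphenyl)carbonyl group. Within the data shown here, no step between measured compounds is available here to guide how such an addition plays out in this assay, so the expectation rests on the value of compound 2 alone, and a change no larger than the usual scatter, in either direction, is what is expected. Compound 3 is therefore estimated at 20 nM, with a range from 6 nM to 70 nM, which corresponds to an expected step of a 1.1-fold higher number from compound 2 to compound 3 (0.05 log units; within the scatter).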

Compound 3, half-maximal inhibitory concentration: 17 nM
For compound 3 the middle estimate is 1.2-fold (0.07 log units) above the measured one, within the range that was stated.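

Going from benzoyl to (4-methoxyphenyl)carbonyl gives a 1.1-fold lower number from compound 2 to compound 3 (0.02 log units; within the scatter) in this assay, and this step lies within the scatter. Among these compounds, this is the first step that can be read between two measured compounds, and it shows that this aromatic carbon, para to a large group, can carry a methoxy without any measurable difference in binding between compound 2 and compound 3. Nothing measured here explains why the values stay so close.

From the compounds shown here alone, one step at one carbon says little about other groups, so it remains open whether an amine, a carboxylic acid or a longer chain such as butoxy would be accepted at the same place. Going by these compounds, it also remains open whether a methoxy on another carbon of the same aromatic ring would give a similar result.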